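The compounds below may be only part of what the source reports. "The series", "measured", "known", "first", "only" and "open" are said of these compounds alone.

Measured compounds:
compound 1 `Clc1cccc2c1CC2CCN1CCN(c2cccc3c2OCCO3)CC1` gives 1.25 mg/kg
compound 2 `c1ccc2c(c1)CC(CCN1CCN(c3cccc4c3OCCO4)CC1)C2` gives 0.16 mg/kg

Going by the values given here, in a functional assay on the whole organism for antagonist activity, with Rattus norvegicus as the target (on this read-out lower numbers stand for an effect already at smaller amounts and higher numbers for an effect only at larger amounts of compound), compound 2 stands at the lowest of the two numbers; the only other compound, compound 1, lies above it by the one measured step, a 7.8-fold lower number from compound 1 to compound 2 (0.89 log units; beyond the scatter). That step, however, swaps the whole ring group and removes the chlorine at once, so it does not isolate any single feature.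

Compound 3 `C1=C(CCN2CCN(c3cccc4c3OCCO4)CC2)Cc2ccccc21` has not been measured. It differs from compound 2 in one place: a group of 9 heavy atoms (9 carbon; one five-membered non-aromatic ring of carbon only, one six-membered aromatic ring of carbon only) in place of a group of 9 heavy atoms (9 carbon; one five-membered non-aromatic ring of carbon only, one six-membered aromatic ring of carbon only), on a saturated chain carbon, two bonds along the chain from an amine nitrogen in a ring. Among the compounds with values here, no measured step touches a double bond of this kind, so nothing among the measured compounds bears directly on the change, and the group keeps its size and ring count. A step of no size beyond the scatter is therefore expected, described as a 1.3-fold higher number from compound 2 to compound 3 (0.10 log units; within the scatter). Compound 3 is estimated to give 0.2 mg/kg in this assay. Its range is expected to run from 0.07 mg/kg to 0.6 mg/kg.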

Compound 3, minimum effective dose: 0.31 mg/kg
The estimate for compound 3 lay 1.6-fold (0.19 log units) below the measured number, within the range that was stated.
By their numbers in this assay, from the lowest: compounds 2 and 3 (each within the scatter of the next); then compound 1.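

In this assay, a group with one double bond outside aromatic rings replaces 2,3-dihydro-1H-inden-2-yl in a 1.9-fold higher number from compound 2 to compound 3 (0.29 log units; within the scatter), so on this saturated chain carbon, two bonds along the chain from an amine nitrogen in a ring, adding this double bond brings no change that can be told from the scatter. The unsaturated group also stays clearly apart from the chlorine-bearing group with the four-membered ring, with a 4.0-fold lower number from compound 1 to compound 3 (0.61 log units; beyond the scatter), so both groups with a five-membered ring differ from compound 1 in the same direction. Nothing available explains why the double bond leaves the number within the scatter.

From the compounds shown here alone, both steps from compound 1 change ring size and remove chlorine together, so the part each change plays stays open. A chlorine on the 2,3-dihydro-1H-inden-2-yl group, or a longer chain to the amine nitrogen, would be needed to address this position further.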